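The source may hold more compounds than are shown below. What is called first, only, known or untested is meant among the compounds shown, and "the series" means these compounds.

Working notes on the series.

Compound 3 `COc1ccccc1-c1cn2ccnc2c(-c2ccc3ncn(C4CCCCC4)c3c2)n1` gives 11.1% in a functional assay on HT-29 cells (Homo sapiens) for inhibition, read by sulforhodamine B assay, with a stated time of 48 h, tested at 10 uM (on this read-out higher numbers stand for more inhibition at the one concentration tested (going by the name of the read-out) and lower numbers for less inhibition), the lowest of the three measured numbers; compound 2 `Brc1ccc(-c2cn3ccnc3c(-c3ccc4ncn(C5CCCCC5)c4c3)n2)cc1`, at 20.9%, sits within the scatter of it, while compound 1 `COc1ccc(-c2cn3ccnc3c(-c3ccc4ncn(C5CCCCC5)c4c3)n2)cc1`, at 92.5%, stands far above. Compound 4 `FC(F)(F)c1cccc(-c2cn3ccnc3c(-c3ccc4ncn(C5CCCCC5)c4c3)n2)c1` differs from compound 3 in one place: 3-(trifluoromethyl)phenyl in place of 2-methoxyphenyl on an aromatic carbon. Going by the values given here, no measured step involves a trifluoromethyl group or a meta substituent, so the bearing steps are indirect: a number 81.4 percentage points lower from compound 1 to compound 3 (beyond the scatter) and a number 71.6 percentage points lower from compound 1 to compound 2 (beyond the scatter), both large, and a number 9.8 percentage points lower from compound 2 to compound 3 (within the scatter), within the scatter. Both departures from the 4-methoxyphenyl of compound 1 gave low numbers, and compound 4 also lacks that group. Compound 4 is therefore expected to stay low, with a number 13.9 percentage points higher from compound 3 to compound 4 (beyond the scatter) likely inside the scatter. Estimate for compound 4: 25%, range 5% to 60%.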

Compound 4, a percentage reported as inhibition, at one concentration (the size of the read-out at that concentration, not a potency): 6.41%
Compound 4: the middle estimate sits 18.6 percentage points above what was measured; measured number inside the range.
By their numbers in this assay, from the lowest: compounds 4, 3 and 2 (each within the scatter of the next, the first and the last beyond it); then compound 1.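

For the 3-(trifluoromethyl)phenyl group at this position, this assay shows a number 4.7 percentage points lower from compound 3 to compound 4 (within the scatter) and a number 14.5 percentage points lower from compound 2 to compound 4 (beyond the scatter) and also a number 86.1 percentage points lower from compound 1 to compound 4 (beyond the scatter) on this aromatic carbon. Going by these compounds alone, a third replacement of the 4-methoxyphenyl thus reads low, now with a different group at a different place on the phenyl ring, leaving compound 1 the only high number of the four. Nothing measured speaks to the reason for this.

Open, going by these compounds, is whether the high number of compound 1 is specific to the methoxy group. A 4-hydroxyphenyl, 4-ethoxyphenyl or 4-aminophenyl group at this position would test that.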